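The source may hold more compounds than are shown below. What is called first, only, known or untested is meant among the compounds shown, and "the series" means these compounds.

Compound 1 `CC1=CCC[C@H]2[C@](C)(CC3=CC(=O)C=C(N[C@@H](C(=O)O)C(C)C)C3=O)[C@@H](C)CC[C@]12C` — 11400 nM
Compound 2 `C[C@H](NC1=CC(=O)C=C(C(C)(C)C)C1=O)C(=O)O` — 20100 nM

In a functional assay on Fem-X cells (Homo sapiens) for cytotoxicity, read by MTT assay, with a stated time of 72 h (a higher number here means a weaker inhibitor, a lower number a stronger inhibitor), compound 1 gives 11400 nM, the lower of the two numbers, while compound 2 gives 20100 nM, a gap that lies within the scatter of repeated measurements, so neither compound can be ranked ahead of the other. Compound 3 `CSCC[C@H](NC1=CC(=O)C=C(C[C@]2(C)[C@@H](C)CC[C@]3(C)C(C)=CCC[C@@H]23)C1=O)C(=O)O` differs from compound 1 in one place: 1-carboxy-3-(methylsulfanyl)propyl in place of 1-carboxy-2-methylpropyl on an amine nitrogen. For the measured compounds named here, no measured pair shows what this change does, so compound 3 is expected to stay close to compound 1, with a 1.1-fold higher number from compound 1 to compound 3 (0.04 log units; within the scatter) not beyond the scatter. The estimate for compound 3 is 12500 nM, in the range 5000 nM to 32000 nM.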

Compound 3, half-maximal inhibitory concentration: 19400 nM
Beside the measured number, compound 3's estimate is 1.6-fold (0.19 log units) below it, within the range that was stated.
By their numbers in this assay, from the lowest: compounds 1, 3 and 2 (each within the scatter of the next).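

At the amine nitrogen, putting 1-carboxy-3-(methylsulfanyl)propyl in place of 1-carboxy-2-methylpropyl gives, in this assay, a 1.7-fold higher number from compound 1 to compound 3 (0.23 log units; within the scatter). This is the only pair shown that differs in one place, and it shows that this exchange, which brings a sulfur into the chain, leaves the two compounds indistinguishable in this read-out. Nothing available bears on this result.

The compounds shown leave open whether a chain ending in an amine, or a phenyl group on that chain, would give a step beyond the scatter. They also leave open what an amide in place of the carboxylic acid would do.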